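This account rests on a few compounds, and the source may have more. Where it says the series, first, only, none or still open, it means among the compounds named here.

Measured so far in a functional assay on MDA-MB-231 cells (Homo sapiens) for antiproliferative activity, read by MTT assay, with a stated time of 24 h; a lower number here means a stronger inhibitor, a higher number a weaker inhibitor:
- compound 1 `Cc1cccc(NNC(=O)c2ccc(NS(=O)(=O)c3cnc(O)nc3O)cc2)c1`: > 20000 nM
- compound 2 `O=C(NNc1ccccc1Cl)c1ccc(NS(=O)(=O)c2cnc(O)nc2O)cc1`: 4010 nM
- compound 3 `O=C(NNc1cccc(Cl)c1)c1ccc(NS(=O)(=O)c2cnc(O)nc2O)cc1`: 17400 nM

The value of compound 1 is a limit of the assay. Of the two actual numbers, the higher belongs to compound 3 at 17400 nM, so it is the weaker of the pair.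

Compound 4 `O=C(NNc1ccccc1F)c1ccc(NS(=O)(=O)c2cnc(O)nc2O)cc1` is next, with this change from compound 3: 2-fluorophenyl in place of 3-chlorophenyl on an amine nitrogen. In words, 2-fluorophenyl takes the place of 3-chlorophenyl on an amine nitrogen.

The most relevant step is a 4.3-fold higher number from compound 2 to compound 3 (0.64 log units; beyond the scatter), which swaps 2-chlorophenyl for 3-chlorophenyl. The step of an at least 4.9-fold lower number from compound 1 to compound 2 (0.69 log units; beyond the scatter) also favours compound 2, while an at least 1.1-fold lower number from compound 1 to compound 3 (0.06 log units; that floor lies within the scatter) shows no change beyond the scatter. For the measured compounds named here, no measured step swaps chloro for fluoro, so the 2-chlorophenyl gain is only partly carried over, and a modest move to a lower number is expected in this assay.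

The expected step is a 2.5-fold lower number from compound 3 to compound 4 (0.40 log units; beyond the scatter).

Compound 4 is estimated at 7000 nM, with an expected range of 2500 nM to 20000 nM.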

Compound 4, half-maximal inhibitory concentration: > 20000 nM
Compound 4 was reported as a limit; the forecaster's own chance of this, stated with the estimate: 10%; middle value at least 2.8-fold (0.45 log units) away from the limit.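

In this assay compound 4 gives > 20000 nM, which is a limit of the assay and not a number. With fluoro in place of chloro on an aromatic carbon, the step reads an at least 4.9-fold higher number from compound 2 to compound 4 (0.69 log units; beyond the scatter), so the activity of the 2-chlorophenyl compound is not kept by 2-fluorophenyl, and the identity of the halogen matters in this pair. The step of an at least 1.1-fold higher number from compound 3 to compound 4 (0.06 log units; that floor lies within the scatter) sets no order between those two compounds, and the step involving compound 1 cannot be read, since both of its values are limits: the limit of > 20000 nM in this assay, at which 2 of the 4 values shown sit.

Going by these compounds, how far compound 4 lies past the limit remains unknown, which leaves the full size of the chloro to fluoro loss open. On these data alone, whether the higher activity of compound 2 extends to 2-bromophenyl or 2-methoxyphenyl also remains open.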